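Half-life after swapping pyridin-4-yl for methyl

The compounds below may be only part of what the source reports. "The series", "measured", "known", "first", "only" and "open" are said of these compounds alone.

Measured in an ADME assay on cells (Hepatocyte, Homo sapiens) for metabolic stability; on this read-out higher numbers stand for a longer-lived compound and lower numbers for a shorter-lived compound:
Compound 1 `O=c1cc(N2CCN(CC3CCC(NS(=O)(=O)c4ccccc4)CC3)CC2)sc2c([N+](=O)[O-])cc(C(F)(F)F)cc12`: > 1.55 h (a limit)
Compound 2 `O=C(OC1CCC(CN2CCN(c3cc(=O)c4cc(C(F)(F)F)cc([N+](=O)[O-])c4s3)CC2)CC1)c1ccncc1`: 0.075 h

Going by the values given here, compound 2 holds the only true number in this assay, at 0.075 h. The reading for compound 1 is a limit, > 1.55 h.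

The next compound is compound 3 `CC(=O)OC1CCC(CN2CCN(c3cc(=O)c4cc(C(F)(F)F)cc([N+](=O)[O-])c4s3)CC2)CC1`. Its difference from compound 2 is methyl in place of pyridin-4-yl on a carbonyl carbon, or (pyridin-4-yl)carbonyl to acetyl.

Among the compounds with values here, one measured step bears on this only in part: an at least 20-fold lower number from compound 1 to compound 2 (1.31 log units; beyond the scatter), a large step with ((pyridin-4-yl)carbonyl)oxy in place of (phenylsulfonyl)amino on a saturated ring carbon. Compound 3 keeps the carbonyl and its oxygen at that place. Within the data shown here, no measured step changes the group on that carbonyl alone, so the expectation stays close to compound 2 at 0.075 h. The expected change is a 1.3-fold higher number from compound 2 to compound 3 (0.12 log units; within the scatter), which is not expected to lie beyond the scatter. For compound 3 the estimated half-life is 0.1 h, with an expected range of 0.035 h to 0.3 h.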

Compound 3, half-life: < 0.15 h
Compound 3 gave a limit, no number; the forecaster's own chance of this, stated with the estimate: 5%; the middle value lies beyond the limit too.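

In this assay compound 3 gives < 0.15 h, which is a limit and not a number. With acetoxy in place of (phenylsulfonyl)amino on a saturated ring carbon, the data show an at least 10-fold lower number from compound 1 to compound 3 (1.01 log units; beyond the scatter), so a large step at this place appears with methyl on the carbonyl carbon as well as with pyridin-4-yl. The step between compound 2 and compound 3 cannot be read, because compound 3 stands at a limit: the limit of < 0.15 h in this assay, at which 1 of the 3 values shown sits.

From the compounds shown here alone, how far methyl and pyridin-4-yl on the carbonyl carbon actually lie apart therefore stays open. Also open, going by these compounds, is how an acetylamino group on the same saturated ring carbon would read, which would tell whether the large step goes with the ester oxygen or with the loss of the phenylsulfonyl group.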